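Sulfamoyl carbamates on the diisopropylphenyl core: next step

The compounds below may be only part of what the source reports. "The series", "measured", "known", "first", "only" and "open" are said of these compounds alone.

Compound 2 `CC(C)c1cccc(C(C)C)c1OC(=O)NS(=O)(=O)Nc1ccccc1` gives 38100 nM in an assay on liver for inhibition of sterol O-acyltransferase 1 (Rattus norvegicus), using microsomes (a higher number here means a weaker inhibitor, a lower number a stronger inhibitor), and compound 1 `CCCCCCNS(=O)(=O)NC(=O)Oc1c(C(C)C)cccc1C(C)C` gives 21000 nM, the two not separated beyond the scatter. Compound 3 `Cc1cccc(C)c1OS(=O)(=O)NC(=O)Oc1c(C(C)C)cccc1C(C)C` differs from compound 2 by 2,6-dimethylphenoxy in place of anilino on a sulfonyl sulfur. Among the measured compounds shown here, the only measured step, a 1.8-fold higher number from compound 1 to compound 2 (0.26 log units; within the scatter), changed the group on the sulfonamide nitrogen and hardly moved the number; no step touches the exchange of an anilino for a phenoxy group on the sulfonyl sulfur, so nothing beyond the scatter is expected in this assay. The estimate for compound 3 is 32000 nM (range 8000 nM to 130000 nM), an expected step of a 1.2-fold lower number from compound 2 to compound 3 (0.08 log units; within the scatter).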

Compound 3, half-maximal inhibitory concentration: > 50000 nM
Compound 3 ended at the assay's limit (the forecaster's own chance of this, stated with the estimate: 25%); middle value at least 1.5-fold (0.19 log units) away from the limit.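

Compound 3 reads only as a limit in this assay: the limit of > 50000 nM in this assay, at which 1 of the 3 values shown sits.

On the sulfonyl sulfur, 2,6-dimethylphenoxy gives an at least 2.3-fold higher number from compound 1 to compound 3 (0.37 log units; beyond the scatter) against hexylamino, and an at least 1.3-fold higher number from compound 2 to compound 3 (0.11 log units; that floor lies within the scatter) against anilino. This position, where hexylamino and anilino stayed within the scatter of each other, therefore does respond to a change, though only the comparison with hexylamino can be read as beyond the scatter.

On these data alone, how far compound 3 lies past its limit remains open, and with it the full size of both steps. Also open, as far as these compounds go, is whether plain phenoxy or a benzylamino group on the sulfonyl sulfur would match anilino or 2,6-dimethylphenoxy.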